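This account rests on a few compounds, and the source may have more. Where it says the series, first, only, none or still open, it means among the compounds named here.

Measured compounds:
compound 1 `O=C(O)C[C@H](O)C[C@H](O)CCn1c(C(F)(F)F)nc(-c2ccccc2)c1-c1ccc(F)cc1`: 31 nM
compound 2 `O=C(O)C[C@H](O)C[C@H](O)CCn1c(C(F)(F)F)nc(-c2ccc(F)cc2)c1-c1ccc(F)cc1`: 38 nM

In an assay on microsomes from liver for inhibition of 3-hydroxy-3-methylglutaryl-coenzyme A reductase (Rattus norvegicus) (on this read-out lower numbers stand for stronger inhibition and higher numbers for weaker inhibition), compound 1 gives 31 nM and compound 2 gives 38 nM. Within the data shown here, the only step between them, a 1.2-fold higher number from compound 1 to compound 2 (0.09 log units; within the scatter), comes from a fluoro in place of hydrogen on an aromatic carbon, so the two numbers cannot be told apart, and compound 2 stands level with compound 1.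

Compound 3 `COc1cccc(-c2c(-c3ccc(F)cc3)nc(C(F)(F)F)n2CC[C@@H](O)C[C@@H](O)CC(=O)O)c1` keeps the shared core of compound 2 and differs in one place: 3-methoxyphenyl in place of 4-fluorophenyl on an aromatic carbon. Among the measured compounds shown here, the single measured step touches the same ring, exchanging one substituent on it for another, and it was small. Replacing the whole ring substituent pattern is a larger change than that step, so it gives only a loose guide. The expectation is a step of about a 1.2-fold higher number from compound 2 to compound 3 (0.07 log units; within the scatter) from compound 2 to compound 3 in this assay, with no confident direction. Compound 3 is therefore estimated at 45 nM, within a range from 15 nM to 135 nM.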

Compound 3, half-maximal inhibitory concentration: 135 nM
Beside the measured number, compound 3's estimate is 3.0-fold (0.48 log units) below it; the range from low to high includes it.
By their numbers in this assay, from the lowest: compounds 1 and 2 (each within the scatter of the next); then compound 3.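

In this assay, among these compounds, the move to 3-methoxyphenyl brings a 3.6-fold higher number from compound 2 to compound 3 (0.55 log units; beyond the scatter) and so gives the first step here that lies beyond the scatter, though a modest one. The earlier exchange of hydrogen for fluoro on this same ring could not be told from the scatter, whereas this change shows that the number can respond to what the ring at this place carries. Nothing measured here explains why the number rose.

The step removes a fluoro and brings in a methoxy group at once, and the compounds shown cannot separate the two changes. As far as these compounds go, how this place would respond to a ring carrying a hydroxyl group, an amine or a longer ether chain also remains open.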